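Removing the Methyl from the Methoxy Group of Compound 2

The source may report more compounds than this note shows. Statements on the series, on what has been measured and on what is new or still open speak of the compounds shown alone.

Compound 2 `COc1cc(-c2nn(-c3cccc(NC(=O)Nc4cc(C(F)(F)F)cc(C(F)(F)F)c4)c3)cc2-c2ccncc2)ccc1Cl` is the only one of the three measured compounds with a number in a functional assay on A549 cells (Homo sapiens) for inhibition, read by sulforhodamine B assay, with a stated time of 48 h; on this read-out lower numbers stand for higher toxicity in this test and higher numbers for lower toxicity in this test: compound 2 gives 18000 nM. Compound 1 `O=C(Nc1cccc(-n2cc(-c3ccncc3)c(-c3ccc(Cl)c(O)c3)n2)c1)Nc1cccc(C(F)(F)F)c1` reaches only a limit of this assay, > 32500 nM. Compound 3 `COc1cc(-c2nn(-c3cccc(NC(=O)Nc4cccc(C(F)(F)F)c4)c3)cc2-c2ccncc2)ccc1Cl` likewise reaches only a limit, > 50000 nM. Compound 4 `O=C(Nc1cccc(-n2cc(-c3ccncc3)c(-c3ccc(Cl)c(O)c3)n2)c1)Nc1cc(C(F)(F)F)cc(C(F)(F)F)c1` differs from compound 2 by hydrogen in place of methyl on an oxygen on an aromatic ring. The matching change between measured compounds gives a step that the two limits leave unreadable from compound 1 to compound 3, so it cannot guide the expectation; the other measured step, an at least 2.7-fold higher number from compound 2 to compound 3 (0.44 log units; beyond the scatter), concerns a different group. With no readable step bearing on the change, compound 4 is expected to stay close to compound 2. The estimated step is a 1.1-fold higher number from compound 2 to compound 4 (0.05 log units; within the scatter). Compound 4 is therefore estimated at 20000 nM, within 8000 nM to 50000 nM.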

Compound 4, concentration lethal to 50% of the cells: 11400 nM
The estimate for compound 4 lay 1.8-fold (0.24 log units) above the measured number, within the range that was stated.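

In this assay, among the compounds shown here, hydroxy in place of methoxy gives the first readable step for this change: a 1.6-fold lower number from compound 2 to compound 4 (0.20 log units; within the scatter). With the hydroxy kept, trifluoromethyl in place of hydrogen on an aromatic carbon gives an at least 2.8-fold lower number from compound 1 to compound 4 (0.45 log units; beyond the scatter). This change can now be followed with either methoxy or hydroxy present: the same change on two cores in this assay, an at least 2.7-fold higher number (0.44 log units; beyond the scatter) from compound 2 to compound 3 and an at least 2.8-fold higher number (0.45 log units; beyond the scatter) from compound 4 to compound 1; the limit leaves it open whether they differ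

The matching methoxy to hydroxy step between compound 1 and compound 3 cannot be read, as both give only limits. Going by these compounds, whether an ethyl group on that oxygen, or an amine in place of the hydroxy, would shift the number remains open.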